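The compounds below may be only part of what the source reports. "The series", "measured", "known", "first", "only" and "open" are said of these compounds alone.

Compound 1, `O=C1C=C(NCc2ccccc2)C(=O)c2c1nc1n2[C@H]2OC[C@@H](O)[C@H]2OC1`, is one of three measured compounds. In a functional assay on HeLa cells (Homo sapiens) for inhibition, read by sulforhodamine B assay (on this read-out higher numbers stand for weaker inhibition and lower numbers for stronger inhibition), compound 1 gives > 8000 nM, which is a limit of the assay rather than a number. Compound 2, `O=C1C(Nc2ccccc2)=CC(=O)c2c1nc1n2[C@H]2OC[C@@H](O)[C@H]2OC1`, gives in this assay > 8000 nM, again a limit. Compound 3, `O=C1C(N2CCCC2)=CC(=O)c2c1nc1n2[C@H]2OC[C@@H](O)[C@H]2OC1`, gives in this assay > 16000 nM, also a limit.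

Compound 1 therefore stands only at a limit, and the two other values shown are limits as well: the limit of > 8000 nM in this assay, at which 2 of the 3 values shown sit, and (the limit of > 16000 nM in this assay, at which 1 of the 3 values shown sits). Among the compounds with values here, the single step among the measured compounds, a step that the two limits leave unreadable from compound 2 to compound 3, cannot be sized.

The step of interest leads from compound 1 to compound 4, `CCCN(CCC)C1=CC(=O)c2nc3n(c2C1=O)[C@H]1OC[C@@H](O)[C@H]1OC3`, through the change (dipropylamino in place of benzylamino on a double-bonded ring carbon). Within the data shown here, no measured step bears readably on this change, and no evidence points in either direction. The three measured compounds all sit at limits, so an account of compound 4 can only rest on that. Compound 4 is expected to behave like them, with an estimated 12000 nM in this assay, ranging from 4000 nM to 40000 nM. The expected step that the limit leaves unreadable from compound 1 to compound 4 is thus estimated to show no change beyond the scatter, and most likely compound 4 will again be reported only as a limit.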

Compound 4, half-maximal inhibitory concentration: > 16000 nM
Compound 4 gave a limit, no number; the forecaster's own chance of this, stated with the estimate: 80%; middle value at least 1.3-fold (0.12 log units) away from the limit.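

Within the data shown here, compound 1 and compound 4 both stand only at limits, so the change from compound 1 to compound 4 yields no step that can be read. The compounds shown leave open how strongly any of them acts in this assay, and whether dipropylamino and benzylamino differ at all.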